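Aryl Substituent Swaps on a Shared Core Change Little

This account rests on a few compounds, and the source may have more. Where it says the series, first, only, none or still open, it means among the compounds named here.

In a functional assay on MDA-MB-231 cells (Homo sapiens) for inhibition, read by MTT assay, with a stated time of 72 h (on this read-out lower numbers stand for stronger inhibition and higher numbers for weaker inhibition), compound 3 `C=CC(=O)Nc1cccc(NC(=O)CSc2nc(Nc3cccc(C)c3)c3ccccc3n2)c1` gives 16800 nM, the second highest of the three numbers, while compound 1 `C=CC(=O)Nc1cccc(NC(=O)CSc2nc(Nc3cccc(Cl)c3)c3ccccc3n2)c1` gives 16300 nM and compound 2 `C=CC(=O)Nc1cccc(NC(=O)CSc2nc(Nc3cccc(Br)c3)c3ccccc3n2)c1` gives 19400 nM, both within the scatter of compound 3. The steps of a 1.2-fold higher number from compound 1 to compound 2 (0.08 log units; within the scatter), a 1.0-fold higher number from compound 1 to compound 3 (0.01 log units; within the scatter) and a 1.2-fold lower number from compound 2 to compound 3 (0.06 log units; within the scatter) each alter the same aromatic ring and none leaves the scatter. Compound 4 `C=CC(=O)Nc1cccc(NC(=O)CSc2nc(Nc3ccc(C(F)(F)F)cc3)c3ccccc3n2)c1` differs from compound 3 by 4-(trifluoromethyl)phenyl in place of 3-methylphenyl on a nitrogen on an aromatic ring. Because a 1.0-fold higher number from compound 1 to compound 3 (0.01 log units; within the scatter) and the other two steps on that ring stayed within the scatter, the expected step of a 1.0-fold higher number from compound 3 to compound 4 (0.01 log units; within the scatter) is likewise no larger than the scatter. Compound 4 is therefore expected in this assay to give 17000 nM, ranging from 7500 nM to 38000 nM.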

Compound 4, half-maximal inhibitory concentration: 11500 nM
The estimate for compound 4 lay 1.5-fold (0.17 log units) above the measured number; the measured number falls inside the stated range.
By their numbers in this assay, from the lowest: compounds 4, 1, 3 and 2 (each within the scatter of the next).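

Replacing 3-methylphenyl, 3-chlorophenyl or 3-bromophenyl with 4-(trifluoromethyl)phenyl in this assay gives a 1.5-fold lower number from compound 3 to compound 4 (0.16 log units; within the scatter), a 1.4-fold lower number from compound 1 to compound 4 (0.15 log units; within the scatter) and a 1.7-fold lower number from compound 2 to compound 4 (0.23 log units; within the scatter). Unlike the earlier steps, these change both the substituent and where it sits on the ring, yet each remains within the scatter. No supporting measurement bears on this result.

The compounds shown leave open whether an amine or a carboxylic acid on this ring would also stay within the scatter. They also leave open whether any change at this position can move the number beyond it.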